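Chloro to Bromo Swap and Expected Solubility of Compound 4

This account rests on a few compounds, and the source may have more. Where it says the series, first, only, none or still open, it means among the compounds named here.

For the measured compounds named here, compound 1, `COc1cc([N+](=O)[O-])ccc1NC(=O)c1cc(Cl)ccc1O`, is the only compound here with a number in a physicochemical assay for solubility; on this read-out higher numbers stand for higher solubility and lower numbers for lower solubility; compound 1 gives 9.2 ug/mL. Compound 2, `O=C(Nc1ccc(C(F)(F)F)cc1Cl)c1cc(Cl)ccc1O`, reports in this assay only a limit, < 1 ug/mL. Compound 3, `O=C(Nc1ccc(C(F)(F)F)cc1Cl)c1cc(Br)ccc1O`, likewise reports in this assay only a limit, < 1 ug/mL. The change between them is bromo in place of chloro on an aromatic carbon, and it gives a step that the two limits leave unreadable from compound 2 to compound 3, unreadable because both values sit at the limit of < 1 ug/mL in this assay, at which 2 of the 3 values shown sit. The difference between the core of compound 1 and the core of compound 2 is not broken down here. Compound 4, `COc1cc([N+](=O)[O-])ccc1NC(=O)c1cc(Br)ccc1O`, is not yet measured; it differs from compound 1 by bromo in place of chloro on an aromatic carbon, the same change that separates compound 2 from compound 3. That measured step gives no size; the expected step of a 1.3-fold lower number from compound 1 to compound 4 (0.12 log units; within the scatter) in this assay is therefore taken as small. Compound 4 is estimated at 7 ug/mL, between 3 ug/mL and 15 ug/mL.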

Compound 4, solubility: 1.6 ug/mL
The estimate for compound 4 lay 4.4-fold (0.64 log units) above the measured number, and the stated range ends above it.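

In this assay, bromo in place of chloro on an aromatic carbon, on the core of compound 1, gives a 5.8-fold lower number from compound 1 to compound 4 (0.76 log units; beyond the scatter). The same change from compound 2 to compound 3 cannot be read, because both compounds report only a limit: the limit of < 1 ug/mL in this assay, at which 2 of the 4 values shown sit. The size of the step is therefore known on the core of compound 1 alone, and the data neither support nor rule out a step of similar size on the other core.

The compounds shown leave open whether the step would hold on a further core whose values stand clear of the limit. They also leave open how an amine or a carboxylic acid in place of the halogen would read on the core of compound 1.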